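The compounds below may be only part of what the source reports. "The series", "measured", "known", "first", "only" and "open" are said of these compounds alone.

In an assay on membranes from brain for displacement of a labelled ligand from adenosine receptor A1 (Rattus norvegicus), read by scintillation counting, with a stated time of 90 min (a higher number here means a weaker inhibitor, a lower number a stronger inhibitor), compound 2 `COc1cccc(CCC(=O)Nc2nc3ccccc3c(=O)s2)c1` gives 367 nM. Among the two numbers on hand this is the higher one; the nearest neighbour, compound 1 `O=C(CCCc1ccccc1)Nc1nc2cc(Cl)ccc2c(=O)s1`, gives 64.4 nM, a gap wide enough to lie beyond the usual scatter of this assay. Compound 3 `O=C(/C=C/c1cccc(Cl)c1)Nc1nc2ccccc2c(=O)s1` gives >= 10000 nM, which is a limit of the assay rather than a number.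

Compound 4 `O=C(CCc1ccc(Cl)c(Cl)c1)Nc1nc2ccccc2c(=O)s1` has not yet been measured in this assay. Set against compound 2 it differs in one place: 3,4-dichlorophenyl in place of 3-methoxyphenyl on a saturated chain carbon, two bonds along the chain from a carbonyl carbon. Among the compounds with values here, no pair of measured compounds differs by just this change, so no measured step shows what to expect of it; the three measured compounds differ from one another in several places at once, and the wide spread among them, from the value of compound 1 up to the limit of compound 3, only shows that this side chain matters. A step from compound 2 to compound 4 of modest size is expected, toward a lower number, estimated at a 1.8-fold lower number from compound 2 to compound 4 (0.26 log units; within the scatter). In this assay compound 4 is expected to give about 200 nM, within a range from 50 nM to 800 nM.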

Compound 4, inhibition constant: > 1500 nM
Compound 4: no number, only a limit (the forecaster's own chance of this, stated with the estimate: 5%); middle value at least 7.5-fold (0.87 log units) away from the limit.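

Within the data shown here, this is the first comparison where only one place changes, so the effect of the ring on this chain can be read directly. In this assay, 3,4-dichlorophenyl in place of 3-methoxyphenyl on a saturated chain carbon, two bonds along the chain from a carbonyl carbon, gives an at least 4.0-fold higher number from compound 2 to compound 4 (0.61 log units; beyond the scatter), so this swap alone is enough to weaken the inhibitor. The result for compound 4 is a limit and not a number, which leaves the full size of the step unknown: the limit of > 1500 nM in this assay, at which 1 of the 4 values shown sits.

The compounds shown cannot separate losing the methoxy group from gaining the two chlorines, and a plain phenyl ring on the same chain would help to tell these apart. They also leave open how an amine or a carboxylic acid on this ring would behave.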